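Quinoxaline sulfones: anilino methoxy pattern and HL-60 cytotoxicity

A few compounds are considered here, and "the series" means these few. Any claim that something is new, unique, unknown or untested is made for them only; others in the source may bear on it.

Measured compounds:
Compound 1, `COc1cc(Nc2nc3ccccc3nc2S(=O)(=O)c2ccccc2)cc(OC)c1`: 50 nM
Compound 2, `COc1cc(Nc2nc3ccccc3nc2S(=O)(=O)c2ccccc2)cc(OC)c1OC`: 1770 nM
Compound 3, `Cc1ccc(S(=O)(=O)c2nc3ccccc3nc2Nc2ccccc2)cc1`: 400 nM

In a functional assay on HL-60 cells (Homo sapiens) for cytotoxicity, read by MTT assay, with a stated time of 72 h (on this read-out lower numbers stand for stronger inhibition and higher numbers for weaker inhibition), compound 1 gives 50 nM and stands lowest of the three. Compound 2 carries the change methoxy in place of hydrogen on an aromatic carbon relative to compound 1, and the step of a 35-fold higher number from compound 1 to compound 2 (1.55 log units; beyond the scatter) is the one large movement seen so far. Compound 3, with a different core, gives 400 nM in this assay; the difference between the core of compound 3 and the core of compound 1 is not broken down here, and the two values simply show that compound 3 sits well above compound 1 and well below compound 2.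

Compound 4, `COc1ccc(Nc2nc3ccccc3nc2S(=O)(=O)c2ccc(C)cc2)cc1`, is not yet measured. It differs from compound 3 by methoxy in place of hydrogen on an aromatic carbon. Among the measured compounds shown here, this is the same kind of change as the one from compound 1 to compound 2, but the surroundings of the place differ: in compound 2 the entering methoxy sits ortho to two methoxy groups and para to a large group, whereas in compound 4 it sits only para to a large group, on a ring that otherwise bears hydrogen. For the measured compounds named here, the one measured example of this kind of change cannot be read across directly to a different place on the ring. The expectation for compound 4 is therefore a step of a 1.5-fold higher number from compound 3 to compound 4 (0.18 log units; within the scatter) in this assay, clearly smaller than the step seen from compound 1 to compound 2 and with wide uncertainty, resting only on compound 3 at 400 nM as the starting point. Compound 4 is estimated at 600 nM in this assay, with a plausible range from 150 nM to 2500 nM.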

Compound 4, half-maximal inhibitory concentration: 2790 nM
The estimate for compound 4 lay 4.7-fold (0.67 log units) below the measured number, and the stated range ends below it.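

In this assay, methoxy in place of hydrogen, para to a large group, moves the number the same way in both pairs, with a 7.0-fold higher number from compound 3 to compound 4 (0.84 log units; beyond the scatter) in the new pair and a 35-fold higher number from compound 1 to compound 2 (1.55 log units; beyond the scatter) in the earlier one, so weaker inhibition follows this change on both cores. The direction carries from one core to the other, but the size does not: the same change on two cores in this assay, a 35-fold higher number (1.55 log units; beyond the scatter) from compound 1 to compound 2 and a 7.0-fold higher number (0.84 log units; beyond the scatter) from compound 3 to compound 4, 5.1-fold (0.71 log units) apart, beyond the scatter of two such steps

Among the compounds shown here, these are only two pairs, and they differ in more than one feature: the anilino ring of compound 1 already bears methoxy groups, that of compound 3 bears none, and compound 3 alone has a methyl group on its sulfone-bearing phenyl ring, so the data do not show which feature sets the size of the step, nor how the step would behave on a further core.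

Still open, on these data alone, is whether the loss belongs to methoxy itself or to any group at this place, which a hydroxyl, a fluorine or a methyl there would test. Also open, as far as these compounds go, is whether a single methoxy on the ring of compound 1's sulfone series, without the methyl group of compound 3, gives a step nearer the smaller or the larger one.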